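A few compounds are considered here, and "the series" means these few. Any claim that something is new, unique, unknown or untested is made for them only; others in the source may bear on it.

Measured compounds in a functional assay on HepG2 cells (Homo sapiens) for antiproliferative activity, read by MTT assay, with a stated time of 72 h; on this read-out lower numbers stand for stronger inhibition and higher numbers for weaker inhibition: compound 1 `C=CC(=O)Nc1cc(Nc2nc(C)cc(-c3cn(C)c4ccccc34)n2)c(OC)cc1N(C)CCN(C)C` gives 12600 nM. Compound 2 `C=CC(=O)Nc1cc(Nc2nccc(-c3cn(C)c4ccc(F)cc34)n2)c(OC)cc1N(C)CCN(C)C` gives 429 nM. Compound 3 `CCC/C=C\C(=O)Nc1cc(Nc2nccc(-c3cn(C)c4ccc(F)cc34)n2)c(OC)cc1N(C)CCN(C)C` gives 3400 nM.

Compound 2 has the lowest number of the three, with compound 3 nearest and compound 1 furthest. Compound 4 `C=CC(=O)Nc1cc(Nc2nc(C)cc(-c3cn(C)c4ccc(F)cc34)n2)c(OC)cc1N(C)CCN(C)C` differs from compound 2 by methyl in place of hydrogen on an aromatic carbon. Going by the values given here, no measured step isolates this change. Among the compounds with values here, the only measured step, a 7.9-fold higher number from compound 2 to compound 3 (0.90 log units; beyond the scatter), concerns the vinyl on the carbonyl carbon, not the aromatic carbon in question. Compound 1 carries the same methyl but also lacks the 5-fluoro-1-methyl-1H-indol-3-yl group of compound 2, so its much higher number can only hint that the methyl weakens activity. Compound 4 is therefore expected to show a 7.0-fold higher number from compound 2 to compound 4 (0.84 log units; beyond the scatter) in this assay. The estimated value of compound 4 is 3000 nM, with a range from 800 nM to 12000 nM.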

Compound 4, half-maximal inhibitory concentration: 4280 nM
Compound 4: middle estimate off by 1.4-fold (0.15 log units), on the low side; low and high end bracket the measured number.
By their numbers in this assay, from the lowest: compound 2; then compounds 3 and 4 (each within the scatter of the next); then compound 1.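

In this assay, the methyl on the aromatic carbon next to the ring nitrogen weakens activity on its own, as a 10-fold higher number from compound 2 to compound 4 (1.00 log units; beyond the scatter) shows with nothing else changed. The fluoro step, a 2.9-fold lower number from compound 1 to compound 4 (0.47 log units; beyond the scatter), shows that fluoro in place of hydrogen still lowers the number when this methyl is present. Nothing measured here explains why the methyl has this effect. On these data alone, whether an ethyl, a methoxy or an amine on this carbon would behave like the methyl stays open. So does the methyl's effect alongside the pent-1-en-1-yl group of compound 3.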